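This account rests on a few compounds, and the source may have more. Where it says the series, first, only, none or still open, it means among the compounds named here.

Of the compounds shown here, three that share one core have been tested in a functional assay on U-87MG ATCC cells (Homo sapiens) for cytotoxicity, read by MTT assay, with a stated time of 72 h; a higher number here means a weaker inhibitor, a lower number a stronger inhibitor. Compound 1 `CN(C)CCn1cnnc1-c1cc(Oc2ccc(NC(=O)N/N=C/c3ccc(Cl)cc3Cl)cc2F)ccn1` carries a 2,4-dichlorophenyl group on a carbon with a double bond to nitrogen, and in this assay compound 1 gives 2330 nM. Compound 2 `CN(C)CCn1cnnc1-c1cc(Oc2ccc(NC(=O)N/N=C/c3c[nH]c4ccccc34)cc2F)ccn1` carries a 1H-indol-3-yl group at that carbon, and compound 2 gives 690 nM. Compound 3 `CN(C)CCn1cnnc1-c1cc(Oc2ccc(NC(=O)N/N=C/c3ccccc3)cc2F)ccn1` carries a plain phenyl there, and compound 3 gives 2250 nM. Of these three numbers compound 3 has the second highest: the step of a 1.0-fold lower number from compound 1 to compound 3 (0.02 log units; within the scatter) lies within the scatter, while the step of a 3.3-fold higher number from compound 2 to compound 3 (0.51 log units; beyond the scatter) is modest but beyond it.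

Compound 4 `CN(C)CCn1cnnc1-c1cc(Oc2ccc(NC(=O)N/N=C/c3c(O)ccc4ccccc34)cc2F)ccn1` has not yet been measured. Its change from compound 3 is 2-hydroxynaphthalen-1-yl in place of phenyl on a carbon with a double bond to nitrogen. For the measured compounds named here, two measured steps bear on this. The step of a 1.0-fold lower number from compound 1 to compound 3 (0.02 log units; within the scatter) shows that exchanging one single six-membered ring for another changed nothing. The step of a 3.3-fold higher number from compound 2 to compound 3 (0.51 log units; beyond the scatter) shows that the 1H-indol-3-yl compound 2 sits at a lower number than the phenyl compound 3. The entering group resembles 1H-indol-3-yl in bringing two aromatic rings and one hydrogen-bond donor, so a modest lowering is expected, estimated as a 2.0-fold lower number from compound 3 to compound 4 (0.31 log units; beyond the scatter). Compound 4 is thus expected to give about 1100 nM, within a range from 400 nM to 3000 nM.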

Compound 4, half-maximal inhibitory concentration: 620 nM
Estimate against measurement, compound 4: 1.8-fold (0.25 log units) above; the range from low to high includes it.
By their numbers in this assay, from the lowest: compounds 4 and 2 (each within the scatter of the next); then compounds 3 and 1 (each within the scatter of the next).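

The 2-hydroxynaphthalen-1-yl group shows that a low number at this position does not depend on the 1H-indol-3-yl group alone: in this assay there is a 3.6-fold lower number from compound 3 to compound 4 (0.56 log units; beyond the scatter) and also a 3.8-fold lower number from compound 1 to compound 4 (0.57 log units; beyond the scatter), both modest but beyond the scatter. The two larger groups cannot be told apart here, with a 1.1-fold lower number from compound 2 to compound 4 (0.05 log units; within the scatter). Across these four compounds, the two groups that bring two aromatic rings and one hydrogen-bond donor sit at lower numbers than the two groups with a single ring, and no compound shown goes against this.

Since the 2-hydroxynaphthalen-1-yl group adds both a second aromatic ring and a hydroxyl, the compounds shown cannot separate the contribution of each, and a naphthalen-1-yl without the hydroxyl or a 2-hydroxyphenyl would be needed to pull the two apart. No independent measurement is available to explain why either larger group gives the lower number.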